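A few compounds are considered here, and "the series" means these few. Any claim that something is new, unique, unknown or untested is made for them only; others in the source may bear on it.

compound 1 `CC(=O)Cn1nc(-c2cccnc2)c2ccccc2c1=O`: 40700 nM
compound 2 `CC(=O)OCCn1nc(-c2cccnc2)c2ccccc2c1=O`: 9770 nM
compound 3 `O=c1c2ccccc2c(-c2cccnc2)nn1CCSc1ccccc1`: 9120 nM

These three compounds share one core and differ only in the chain on its aromatic nitrogen. They were tested in a functional assay (trachea) with Cavia porcellus as the target; on this read-out lower numbers stand for stronger inhibition and higher numbers for weaker inhibition. Compound 3 stands level with compound 2, since the step of a 1.1-fold lower number from compound 2 to compound 3 (0.03 log units; within the scatter) does not separate them. Both have clearly lower numbers than compound 1.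

The next compound is compound 4 `O=c1c2ccccc2c(-c2cccnc2)nn1CCSc1nccs1`. It keeps all of compound 3 except one group: 1,3-thiazol-2-yl in place of phenyl on a sulfur. In words, 1,3-thiazol-2-yl takes the place of phenyl on a sulfur.

For the measured compounds named here, no measured step makes this exact exchange, so the evidence is indirect. The two steps away from the acetyl group were modest: a 4.2-fold lower number from compound 1 to compound 2 (0.62 log units; beyond the scatter) and a 4.5-fold lower number from compound 1 to compound 3 (0.65 log units; beyond the scatter). The most relevant step is a 1.1-fold lower number from compound 2 to compound 3 (0.03 log units; within the scatter), which changed the group at the end of the chain and still left the number within the scatter. Going by the values given here, on that single comparison, a change at the far end of the chain is expected to shift little, although no measured compound carries any ring other than phenyl on the sulfur. The expected change is a 1.0-fold lower number from compound 3 to compound 4 (0.01 log units; within the scatter), which is none beyond the scatter. The estimated value for compound 4 is 9000 nM, with an expected range from 3500 nM to 25000 nM.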

Compound 4, half-maximal inhibitory concentration: 10500 nM
The estimate for compound 4 lay 1.2-fold (0.07 log units) below the measured number, and the stated range covers the measured number.
By their numbers in this assay, from the lowest: compounds 3, 2 and 4 (each within the scatter of the next); then compound 1.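

In this assay, replacing phenyl on the sulfur with 1,3-thiazol-2-yl leaves the result within the scatter (a 1.2-fold higher number from compound 3 to compound 4 (0.06 log units; within the scatter)), so at this position a five-membered aromatic ring with 2 hetero atoms reads the same as a six-membered aromatic ring of carbon only. The (1,3-thiazol-2-yl)sulfanyl chain end also cannot be told apart from acetoxy (a 1.1-fold higher number from compound 2 to compound 4 (0.03 log units; within the scatter)), yet it keeps a modest advantage over the shorter chain ending in acetyl (a 3.9-fold lower number from compound 1 to compound 4 (0.59 log units; beyond the scatter)), which leaves compound 1 as the only one of the four set apart from the rest. Nothing available here explains why these chain ends read alike.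

The compounds shown carry only phenyl and 1,3-thiazol-2-yl on the sulfur, so it remains open whether a saturated ring such as piperidine, an amine or a carboxylic acid at that end would also leave the number unchanged. A longer chain carrying the sulfur, or an oxygen in place of that sulfur, also remains to be compared.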